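Lengthening the methoxy chain: notes on compound 3

The compounds below may be only part of what the source reports. "The series", "measured", "known", "first", "only" and "open" are said of these compounds alone.

Among the compounds with values here, in a physicochemical assay for solubility, in phosphate buffer, measured as kinetic solubility, at pH 7.4, tested at 250 uM (on this read-out lower numbers stand for lower solubility and higher numbers for higher solubility), compound 2 `COCCNc1ccc(C(=O)O)cc1S(=O)(=O)N(C)C` gives 237000 nM, the only actual number so far. Compound 1 `CN(C)S(=O)(=O)c1cc(C(=O)O)ccc1NCCC(C)(C)C` gives > 250000 nM, which is a limit of the assay and not a number.

Compound 3 `COCCCCNc1ccc(C(=O)O)cc1S(=O)(=O)N(C)C` has not yet been measured. It keeps the core of compound 2 and differs only in the side chain: 2-methoxyethyl in place of methoxy on a saturated chain carbon, two bonds along the chain from a nitrogen on an aromatic ring. In words, 2-methoxyethyl stands in place of methoxy on a saturated chain carbon, two bonds along the chain from a nitrogen on an aromatic ring, so that (2-methoxyethyl)amino becomes (4-methoxybutyl)amino.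

Within the data shown here, one measured step bears on this place: an at least 1.0-fold lower number from compound 1 to compound 2 (0.02 log units; that floor lies within the scatter), with methoxy in place of tert-butyl. Among the measured compounds shown here, it gives only a floor, so its true size remains open, and no measured step covers this chain extension. No step beyond the scatter is therefore expected in this assay. The estimated step is a 1.1-fold lower number from compound 2 to compound 3 (0.03 log units; within the scatter). For compound 3 the expected value is 220000 nM, with an estimated range from 120000 nM to 250000 nM.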

Compound 3, solubility: 247000 nM
Compound 3: the middle estimate sits 1.1-fold (0.05 log units) below what was measured; the range from low to high includes it.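

In this assay, within the data shown here, 2-methoxyethyl in place of methoxy on a saturated chain carbon, two bonds along the chain from a nitrogen on an aromatic ring, gives the first step with actual numbers at both ends (a 1.0-fold higher number from compound 2 to compound 3 (0.02 log units; within the scatter)). The (2-methoxyethyl)amino and (4-methoxybutyl)amino side chains therefore read alike here, so this extension of the chain by 2 heavy atoms leaves no step beyond the scatter on the shared core. Against the tert-butyl chain only a floor can be read (an at least 1.0-fold lower number from compound 1 to compound 3 (0.00 log units; that floor lies within the scatter)), because the reading of compound 1 is a limit and not a number: the limit of > 250000 nM in this assay, at which 1 of the 3 values shown sits.

The compounds shown leave open whether an amine, a carboxylic acid or a ring in this side chain would give a step beyond the scatter in this assay. From the compounds shown here alone, it also remains open whether a longer chain than 4-methoxybutyl, or a hydroxyl group in place of the terminal methoxy, would still read alike on the same core.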